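Swapping the Amide of Compound 1 for a Sulfonamide

The source may report more compounds than this note shows. Statements on the series, on what has been measured and on what is new or still open speak of the compounds shown alone.

Compound 1 `Cc1cccc(C(=O)Nc2cccc(/C=C/C(=O)c3nc4ccccc4[nH]3)c2)c1` carries the lowest number of the three measured compounds in a functional assay on HCT-116 cells (Homo sapiens) for antiproliferative activity, read by MTT assay, with a stated time of 48 h (a lower number here means a stronger inhibitor, a higher number a weaker inhibitor), where compound 1 gives 1420 nM. Compound 3 `Cc1cc(C)cc(C(=O)Nc2cccc(/C=C/C(=O)c3nc4ccccc4[nH]3)c2)c1` gives 1550 nM, and the step of a 1.1-fold higher number from compound 1 to compound 3 (0.04 log units; within the scatter) stays within the scatter. Compound 2 `COc1ccc(C(=O)Nc2cccc(/C=C/C(=O)c3nc4ccccc4[nH]3)c2)cc1` gives 4880 nM, and the step of a 3.4-fold higher number from compound 1 to compound 2 (0.54 log units; beyond the scatter) lies beyond it. Compound 4 `Cc1cccc(S(=O)(=O)Nc2cccc(/C=C/C(=O)c3nc4ccccc4[nH]3)c2)c1` differs from compound 1 by (3-methylphenyl)sulfonyl in place of (3-methylphenyl)carbonyl on a nitrogen on an aromatic ring. Among the compounds with values here, none of the measured steps touches this part of the molecule: each of them changes only the ring on the carbonyl carbon, and they offer no direct guide. With the change untested here, only a modest shift toward a higher number is expected, a 2.1-fold higher number from compound 1 to compound 4 (0.32 log units; beyond the scatter). Compound 4 is therefore estimated at 3000 nM, with a likely range from 1000 nM to 9000 nM.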

Compound 4, half-maximal inhibitory concentration: 597 nM
Beside the measured number, compound 4's estimate is 5.0-fold (0.70 log units) above it; the whole stated range lies above it.
By their numbers in this assay, from the lowest: compound 4; then compounds 1 and 3 (each within the scatter of the next); then compound 2.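

Going from the carbonyl to the sulfonyl gives a 2.4-fold lower number from compound 1 to compound 4 (0.38 log units; beyond the scatter) in this assay while the 3-methylphenyl ring stays the same, so the link on this nitrogen can itself move the number, something the earlier steps on the ring alone could not show. The sulfonyl compound also gives a 2.6-fold lower number from compound 3 to compound 4 (0.41 log units; beyond the scatter) and an 8.2-fold lower number from compound 2 to compound 4 (0.91 log units; beyond the scatter) as well, though these two steps change the ring too. No measurement here explains the drop.

Compound 4 is the only sulfonyl compound shown, so it remains open whether the gain carries over to the 4-methoxyphenyl or 3,5-dimethylphenyl rings. Also open, as far as these compounds go, is how a smaller group on this nitrogen, such as methylsulfonyl, would compare.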